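The compounds below may be only part of what the source reports. "The series", "measured", "known", "first", "only" and "open" are said of these compounds alone.

Compound 3 `Cc1ccc(-n2nccn2)c(C(=O)N(C)CCn2ccc(-c3ccc(F)cn3)n2)c1` is the reference point here. In a functional assay on CHO cells for antagonist activity at Orexin/Hypocretin receptor type 1 (Homo sapiens), read by fluorescence and calcium flux, with a stated time of 30 min (on this read-out higher numbers stand for weaker inhibition and lower numbers for stronger inhibition), compound 3 gives 2.27 nM, the lowest number among the three measured compounds, with both neighbours clearly separated from it. Compound 2 `CCN(CCn1ccc(-c2cc(C(F)(F)F)ccn2)n1)C(=O)c1cc(C)ccc1-n1nccn1` gives 28 nM in this assay, and compound 1 `CCN(CCn1ccc(-c2ccc(C(F)(F)F)cn2)n1)C(=O)c1cc(C)ccc1-n1nccn1` gives 48.6 nM; compound 3 therefore stands as the strongest inhibitor of the three.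

Compound 4 `Cc1ccc(-n2nccn2)c(C(=O)N(CCn2ccc(-c3ccc(F)cn3)n2)C(C)C)c1` differs from compound 3 in one place: isopropyl in place of methyl on an amide-type nitrogen, on an amide-type nitrogen whose other neighbours are a carbonyl carbon and a saturated chain carbon. Within the data shown here, the only measured step, a 1.7-fold lower number from compound 1 to compound 2 (0.24 log units; within the scatter), concerns a trifluoromethyl group moved on an aromatic carbon of a different part of the molecule, and it lies within the scatter. Among the measured compounds shown here, no measured step touches the group on the amide nitrogen, so nothing in the data tells how large a change to expect from the move to isopropyl, nor in which direction.

Given this, the estimate for compound 4 leans on compound 3 alone and allows a wide range in either direction. The expected value for compound 4 in this assay is 5 nM, between 1.5 nM and 20 nM, an expected step of a 2.2-fold higher number from compound 3 to compound 4 (0.34 log units; beyond the scatter).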

Compound 4, antagonist equilibrium constant: 38.5 nM
Beside the measured number, compound 4's estimate is 7.7-fold (0.89 log units) below it; measured number above the stated range.
By their numbers in this assay, from the lowest: compound 3; then compounds 2, 4 and 1 (each within the scatter of the next).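

In this assay, placing isopropyl instead of methyl on the amide-type nitrogen gives a 17-fold higher number from compound 3 to compound 4 (1.23 log units; beyond the scatter), so inhibition is clearly weaker with the group of three carbons than with the single carbon. Among these compounds, the only earlier step between compounds differing in one place, a trifluoromethyl group moved on an aromatic carbon, lay within the scatter, so this pair gives the first clear sign that the read-out can respond strongly to a single change, here one that adds only carbon and brings no ring, no hydrogen-bond donor or acceptor and no charge. Nothing measured here explains why this small change has so large an effect.

A single pair gives two points only, so it cannot tell whether inhibition weakens gradually as the group on this nitrogen grows, or whether isopropyl in particular marks a sharp drop. Cyclopropyl, a longer chain such as n-propyl, and the amide hydrogen in place of methyl would each help to show that, and the same change on a different core would show whether the effect holds beyond this one pair.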